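Furan-to-pyrazole exchange on the shared core: expected cytotoxicity

The source may hold more compounds than are shown below. What is called first, only, known or untested is meant among the compounds shown, and "the series" means these compounds.

Compound 1 `Fc1ccc(-c2nn3c(NC4CCCC4)cccc3c2-c2ccco2)cc1` carries a furan-2-yl group on its core, and in an ADME assay on Vero cells (Chlorocebus sabaeus) for cytotoxicity (on this read-out lower numbers stand for higher toxicity in this test and higher numbers for lower toxicity in this test), compound 1 is recorded as "not determined" (no result reported), so it stands without a number in that test. The only measured point in this set is compound 2 `NNc1cc(-c2c(-c3ccc(F)cc3)nn3c(NC4CCCC4)cccc23)ccn1`, a different member of the series, and in this assay compound 2 gives 40000 nM. Among the measured compounds shown here, no difference has been worked out between compound 1 and compound 2, so their pairing says nothing beyond the single value of compound 2.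

Compound 3 `Fc1ccc(-c2nn3c(NC4CCCC4)cccc3c2-c2cn[nH]c2)cc1` is the next compound to be measured. Relative to compound 1 the change is 1H-pyrazol-4-yl in place of furan-2-yl on an aromatic carbon. For the measured compounds named here, no step between measured compounds is known for this series in this assay, so the size of the move from compound 1 to compound 3 cannot be read from data. The expectation is no move beyond the usual scatter of repeated measurements, in either direction.

On that basis compound 3 is estimated to give 40000 nM in this assay, with a range from 15000 nM to 100000 nM.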

Compound 3, half-maximal cytotoxic concentration: 10000 nM
Compound 3: middle estimate off by 4.0-fold (0.60 log units), on the high side; measured number outside the range, below it.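

In this assay the aromatic carbon next to the ring atom that bears the 4-fluorophenyl group now has its first reading: 1H-pyrazol-4-yl in place of 2-(aminoamino)pyridin-4-yl goes with a 4.0-fold lower number from compound 2 to compound 3 (0.60 log units; beyond the scatter), so the group on this carbon can move the number beyond the usual scatter, toward higher toxicity in this test. Going by these compounds, the exchange of furan-2-yl for 1H-pyrazol-4-yl itself cannot be read, since compound 1 has no number in this assay, and the size of that change remains unknown even though compound 3 now gives the series a second value. Among the compounds shown here, nothing measured so far bears on why the number moves between these two groups on the shared core.

One step fixes neither a trend nor a limit for this position, and it does not show whether the lower number follows the five-membered ring or the loss of the 2-(aminoamino)pyridin-4-yl group. A 1-methylpyrazol-4-yl group, a plain pyridin-4-yl group or a phenyl group bearing a carboxylic acid on the same carbon would help to separate these two readings.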